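The source may hold more compounds than are shown below. What is called first, only, known or untested is meant among the compounds shown, and "the series" means these compounds.

Measured in an ADME assay (liver) for metabolic stability, with Liver microsome (Homo sapiens) as the target, using microsomes; a lower number here means slower removal, a higher number faster removal of the compound:
Compound 1 `Cc1cnc(NC(=O)c2cc(Oc3cnc(C(=O)N(C)C)cn3)c3cc(C)oc3c2)cn1`: < 8.5 mL/min/kg (a limit)
Compound 2 `COc1cnc(NC(=O)c2cc(Oc3cnc(C(=O)N(C)C)cn3)c3cc(C)oc3c2)cn1`: < 8 mL/min/kg (a limit)
Compound 3 `Cc1cc2c(Oc3cnc(C(=O)N(C)C)cn3)cc(C(=O)Nc3cnc(C(F)(F)F)cn3)cc2o1`: 16.1 mL/min/kg

Among the compounds with values here, compound 3, at 16.1 mL/min/kg, holds the only true number here. The other two compounds gave limits. Compound 4 `CCc1cnc(NC(=O)c2cc(Oc3cnc(C(=O)N(C)C)cn3)c3cc(C)oc3c2)cn1` carries ethyl in place of trifluoromethyl on an aromatic carbon. Within the data shown here, two measured steps touch the same place: an at least 1.8-fold higher number from compound 1 to compound 3 (0.27 log units; that floor lies within the scatter) and an at least 2.0-fold higher number from compound 2 to compound 3 (0.30 log units; that floor lies within the scatter). Each is only a floor, and each floor lies within the scatter. Ethyl is taken as nearer to the methyl of compound 1 than to trifluoromethyl, so an at least 1.8-fold higher number from compound 1 to compound 3 (0.27 log units; that floor lies within the scatter) is the better guide, read in reverse. The expected step in this assay is small and toward a lower number, a 1.6-fold lower number from compound 3 to compound 4 (0.21 log units; within the scatter), probably within the scatter. For compound 4 the estimate is 10 mL/min/kg, with an expected range of 6 mL/min/kg to 18 mL/min/kg.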

Compound 4, clearance: 12.2 mL/min/kg
Estimate against measurement, compound 4: 1.2-fold (0.09 log units) below, and the stated range covers the measured number.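

In this assay, within the data shown here, going from 5-(trifluoromethyl)pyrazin-2-yl to 5-ethylpyrazin-2-yl gives a 1.3-fold lower number from compound 3 to compound 4 (0.12 log units; within the scatter), the first step at this position between two true numbers, and it does not separate ethyl from trifluoromethyl. The other two steps rest on limits and are floors only: an at least 1.4-fold higher number from compound 1 to compound 4 (0.15 log units; that floor lies within the scatter) and an at least 1.5-fold higher number from compound 2 to compound 4 (0.18 log units; that floor lies within the scatter). Neither therefore separates ethyl from methyl or from methoxy.

On these data alone, how an amine or a longer chain such as butyl would behave at this position stays open. Nothing shown gives a reason for these numbers.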